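Removing the tert-butoxycarbonyl group from compound 3

The source may hold more compounds than are shown below. What is called first, only, known or untested is meant among the compounds shown, and "the series" means these compounds.

Of the compounds shown here, three have been measured in an assay on isolated protein for displacement of a labelled ligand from secreted frizzled-related protein 1 (Homo sapiens), read by fluorescence polarization, with a stated time of 30 min; on this read-out lower numbers stand for stronger inhibition and higher numbers for weaker inhibition. Compound 1 `O=S(=O)(NC1CCN(S(=O)(=O)c2ccccc2)CC1)c1cc(S(=O)(=O)c2ccccc2)ccc1C(F)(F)F` gives 130 nM in this assay, compound 2 `O=C(O)c1cccc(S(=O)(=O)N2CCC(NS(=O)(=O)c3cc(S(=O)(=O)c4ccccc4)ccc3C(F)(F)F)CC2)c1` gives 20 nM, and compound 3 `CC(C)(C)OC(=O)N1CCC(C(=O)N2CCC(NS(=O)(=O)c3cc(S(=O)(=O)c4ccccc4)ccc3C(F)(F)F)CC2)CC1` gives 300 nM. Within the data shown here, the only step between compounds that differ in one place is a 6.5-fold lower number from compound 1 to compound 2 (0.81 log units; beyond the scatter), a change at an aromatic carbon on another part of the shared core. Compound 3 stands at the highest of the three numbers: compound 1 is its nearest neighbour, and compound 2, the lowest of the three, lies furthest from it, both gaps beyond the scatter.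

Compound 4 `O=C(C1CCNCC1)N1CCC(NS(=O)(=O)c2cc(S(=O)(=O)c3ccccc3)ccc2C(F)(F)F)CC1` differs from compound 3 by hydrogen in place of tert-butoxycarbonyl on an amine nitrogen in a ring. Among the measured compounds shown here, no measured step touches this place or this kind of group; the one step on record concerns a carboxy group added elsewhere and so gives no direct guide to what the loss of the tert-butoxycarbonyl group will do. With nothing that bears on it, the step expected from compound 3 to compound 4 is no change at the digits printed from compound 3 to compound 4 (within the scatter), which means no change beyond the scatter, though the uncertainty is wide in both directions. Compound 4 is therefore estimated to give 300 nM in this assay, within a range from 80 nM to 1200 nM.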

Compound 4, half-maximal inhibitory concentration: 120 nM
Estimate against measurement, compound 4: 2.5-fold (0.40 log units) above; the range from low to high includes it.
By their numbers in this assay, from the lowest: compound 2; then compounds 4 and 1 (each within the scatter of the next); then compound 3.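

In this assay, removing the tert-butoxycarbonyl group gives a 2.5-fold lower number from compound 3 to compound 4 (0.40 log units; beyond the scatter), so this large group on the amine nitrogen in the ring is not needed for the binding read-out, and hydrogen at this place goes with the lower number. The two other new steps concern the amine nitrogen in the ring of the shared core: (piperidin-4-yl)carbonyl in place of phenylsulfonyl gives a 1.1-fold lower number from compound 1 to compound 4 (0.03 log units; within the scatter), whereas (piperidin-4-yl)carbonyl in place of (3-carboxyphenyl)sulfonyl gives a 6.0-fold higher number from compound 2 to compound 4 (0.78 log units; beyond the scatter), so among these three compounds only the one bearing the carboxy group stands apart. Nothing available accounts for any of these steps.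

The compounds shown leave open what a small group such as methyl or acetyl would do on the amine nitrogen that carries hydrogen in compound 4, and so whether the step depends on the size of the group that leaves or on the free amine itself. They also leave open whether a carboxylic acid attached to the (piperidin-4-yl)carbonyl group would bring the number towards that of compound 2, at 20 nM.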